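This account rests on a few compounds, and the source may have more. Where it says the series, first, only, none or still open, it means among the compounds named here.

Measured compounds:
compound 1 `c1coc(CNc2nc(NCCCN3CCCC3)nc3ccccc23)c1`: in a functional assay on HT-29 cells (Homo sapiens) for cytotoxicity, read by MTT assay, with a stated time of 2 days, tested at 10 uM (on this read-out lower numbers stand for less inhibition and higher numbers for more inhibition at the one concentration tested (going by the name of the read-out)), compound 1 gives 87.5%
compound 2 `CCCCCNc1nc(NCc2ccco2)c2cc(F)ccc2n1`: in this assay compound 2 gives "not determined" (no result reported)

Going by the values given here, compound 2 stands without a number: nothing measured fixes where it lies, so no step with a size can be stated for it. Compound 3 `COc1ccc(Nc2nc(NCc3ccco3)c3cc(F)ccc3n2)cc1` differs from compound 2 by 4-methoxyphenyl in place of pentyl on a nitrogen on an aromatic ring. Among the compounds with values here, no comparable step between measured compounds is available, so the size and direction of any change in this assay cannot be told in advance. Compound 3 is expected to give about 70% in this assay, with a range from 35% to 95%.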

Compound 3, a percentage reported as inhibition, at one concentration (the size of the read-out at that concentration, not a potency): 86.2%
Estimate against measurement, compound 3: 16.2 percentage points below, and the stated range covers the measured number.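

In this assay, going by these compounds alone, compound 2 carries no number, so no step to compound 3 can be read. The compounds shown leave open what 4-methoxyphenyl in place of pentyl does to inhibition. No evidence bears on this result.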